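The source may report more compounds than this note shows. Statements on the series, on what has been measured and on what is new or still open speak of the compounds shown alone.

In a functional assay on HepG2 cells (Homo sapiens) for cytotoxicity, read by MTT assay, with a stated time of 24 h (on this read-out lower numbers stand for stronger inhibition and higher numbers for weaker inhibition), compound 1 (`O=C1/C(=C/c2ccccc2F)CN(S(=O)(=O)c2ccc(F)cc2)C/C1=C\c1ccccc1F`) gives 7220 nM as its half-maximal inhibitory concentration. Compound 2 (`COc1cc(/C=C2\CN(S(=O)(=O)c3ccc(F)cc3)C/C(=C\c3cc(OC)cc(OC)c3)C2=O)cc(OC)c1`) gives 8100 nM in this assay and compound 3 (`CC(=O)Nc1ccc(S(=O)(=O)N2C/C(=C\c3cccc([N+](=O)[O-])c3)C(=O)/C(=C/c3cccc([N+](=O)[O-])c3)C2)cc1`) gives 7140 nM there. All three numbers lie within the scatter of one another, so compound 1 cannot be told apart from the other two. No two of these compounds differ in only one place, which means that no single change has yet been measured on its own.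

Compound 4 (`N#Cc1ccc(/C=C2\CN(S(=O)(=O)c3ccc(F)cc3)C/C(=C\c3ccccc3F)C2=O)cc1`) alters compound 1 in one place: 4-cyanophenyl in place of 2-fluorophenyl on a double-bonded chain carbon bound to a double-bonded ring carbon. The best guide available is the group as a whole. Within the data shown here, compound 1, compound 2 and compound 3 carry different groups on the shared core, yet none of the three stands apart from the others, and no compound measured so far goes against this. On that limited evidence, no step beyond the scatter is expected in this assay in either direction. The expected step is a 1.0-fold lower number from compound 1 to compound 4 (0.01 log units; within the scatter) and this estimated size stays within the scatter. The estimate for compound 4 is 7000 nM and the expected range runs from 3500 nM to 14000 nM on the same read-out.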

Compound 4, half-maximal inhibitory concentration: 8180 nM
Estimate against measurement, compound 4: 1.2-fold (0.07 log units) below, within the range that was stated.
By their numbers in this assay, from the lowest: compounds 3, 1, 2 and 4 (each within the scatter of the next).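

In this assay, among these compounds, the exchange of 2-fluorophenyl for 4-cyanophenyl on a double-bonded chain carbon bound to a double-bonded ring carbon gives the first single change that can be read on its own (a 1.1-fold higher number from compound 1 to compound 4 (0.05 log units; within the scatter)). The entering group brings a triple bond and a hydrogen-bond acceptor that the leaving group lacks, yet the step stays within the scatter, so this exchange at this place cannot be told apart from no change in this read-out. No measurement is available that would explain this result or link it to any property of either group.

From the compounds shown here alone, what remains open is whether any group at this place can produce a step beyond the scatter, since a single exchange between two substituted phenyl rings cannot settle that; a phenyl ring carrying an amine or a carboxylic acid, or a longer chain such as n-butyl in place of the ring, would probe a different kind of group. Also unsettled is whether the second 2-fluorophenyl group of compound 4 would respond in the same way to the same exchange.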